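Methylated pyrazole: expected potency of compound 3

The source may hold more compounds than are shown below. What is called first, only, known or untested is meant among the compounds shown, and "the series" means these compounds.

Compound 2 `Cc1cc(C)c(NC(=O)N(Cc2ccc(-c3cc[nH]n3)cc2)C2CCCCCC2)c(C)c1` gives 52 nM in an assay on microsomes from intestine for inhibition of acyl-CoA:cholesterol acyltransferase (Oryctolagus cuniculus) (on this read-out lower numbers stand for stronger inhibition and higher numbers for weaker inhibition), the lowest of the two numbers in hand. Its nearest neighbour is compound 1 `Cc1cc(C)c(NC(=O)N(Cc2ccc(N3CCN(C)CC3)cc2)C2CCCCCC2)c(C)c1`, which in this assay gives 57 nM, and the step of a 1.1-fold lower number from compound 1 to compound 2 (0.04 log units; within the scatter) lies within the scatter, so the two are not separated.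

Compound 3 `Cc1cc(C)c(NC(=O)N(Cc2ccc(-c3ccnn3C)cc2)C2CCCCCC2)c(C)c1` differs from compound 2 by 1-methyl-1H-pyrazol-5-yl in place of 1H-pyrazol-3-yl on an aromatic carbon. Within the data shown here, the only measured step, a 1.1-fold lower number from compound 1 to compound 2 (0.04 log units; within the scatter), concerns the same aromatic carbon but exchanges a 4-methylpiperazin-1-yl for the pyrazole; it does not test a methyl on the pyrazole nitrogen, nor the shift from 1H-pyrazol-3-yl to 1-methyl-1H-pyrazol-5-yl. What it does show is that two quite different groups at this carbon return numbers within the scatter of one another, which argues for some tolerance there. No step in either direction beyond the scatter is therefore expected, and the expected step is a 1.2-fold higher number from compound 2 to compound 3 (0.06 log units; within the scatter). Going by these compounds, the estimate for compound 3 in this assay is 60 nM, with a range from 25 nM to 150 nM, the width reflecting that the methylated pyrazole itself is untested.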

Compound 3, half-maximal inhibitory concentration: 24 nM
The estimate for compound 3 lay 2.5-fold (0.40 log units) above the measured number, and the stated range ends above it.
By their numbers in this assay, from the lowest: compound 3; then compounds 2 and 1 (each within the scatter of the next).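

In this assay, the aromatic carbon para to a large group now separates compounds: a 2.2-fold lower number from compound 2 to compound 3 (0.34 log units; beyond the scatter) is a modest step beyond the scatter, whereas the earlier pair of groups at this carbon could not be told apart. The second new step, a 2.4-fold lower number from compound 1 to compound 3 (0.38 log units; beyond the scatter), is also modest and beyond the scatter, so compound 3 has the lowest number of the three and the tolerance suggested earlier does not mean that the carbon is indifferent to its group. The change from 1H-pyrazol-3-yl to 1-methyl-1H-pyrazol-5-yl alters several things at once, adding a methyl on a ring nitrogen, removing the hydrogen-bond donor and moving the point of attachment, so this single step cannot be assigned to any one of them.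

Going by these compounds, it remains open whether the methyl or the attachment point carries the step, which a comparison with 1-methyl-1H-pyrazol-3-yl would help to resolve, and how a larger 1-ethyl group, a plain phenyl ring or a carboxylic acid would read at the same carbon. No measurement at hand gives a reason for the step.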